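This account rests on a few compounds, and the source may have more. Where it says the series, first, only, none or still open, it means among the compounds named here.

Within a functional assay on T47D cells (Homo sapiens) for cytotoxicity, read by sulforhodamine B assay, with a stated time of 48 h (on this read-out higher numbers stand for weaker inhibition of growth and lower numbers for stronger inhibition of growth), compound 1 (`ClCc1cccc(Cn2cnc3c(Cl)nc(Cl)nc32)c1`) gives 1950 nM, the lowest of the three numbers in hand. Compound 3 (`ClCc1ccccc1Cn1cnc2ncnc(Cl)c21`) gives 1990 nM, which lies within the scatter of compound 1, whereas compound 2 (`Nc1nc(Cl)c2ncn(Cc3ccccc3CCl)c2n1`) gives 24000 nM, a gap beyond the scatter. Compound 4 (`ClCc1cccc(Cn2cnc3c(Cl)ncnc32)c1`) awaits measurement in this assay. Set against compound 1 it carries hydrogen in place of chloro on an aromatic carbon. Because compound 3 gives 1990 nM at the level of compound 1 although its core differs from that of compound 1, no step beyond the scatter is expected for compound 4 in this assay. The step from compound 1 to compound 4 is estimated at a 1.3-fold higher number from compound 1 to compound 4 (0.11 log units; within the scatter). For compound 4 the expected value is 2500 nM, with a range from 1000 nM to 6500 nM.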

Compound 4, concentration for 50% growth inhibition: 3020 nM
Estimate against measurement, compound 4: 1.2-fold (0.08 log units) below; low and high end bracket the measured number.
By their numbers in this assay, from the lowest: compounds 1, 3 and 4 (each within the scatter of the next); then compound 2.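

In this assay, the chloro on the aromatic carbon between two ring nitrogen atoms can now be read on its own: the swap to hydrogen gives a 1.5-fold higher number from compound 1 to compound 4 (0.19 log units; within the scatter) and stays within the scatter. With the rest of compound 1 held constant, chloro and hydrogen at this position are not told apart. No measurement on hand accounts for this step. Still open, on these data alone, is whether a methoxy group or a longer alkyl chain at this position would shift the number beyond the scatter. As far as these compounds go, whether the same swap holds with other substitution on the shared core is also open.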